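The compounds below may be only part of what the source reports. "The series", "measured", "known", "first", "only" and "open" are said of these compounds alone.

Compound 1 `COc1ccccc1/C=c1/[nH]c(=O)/c(=C\c2cccc(Cl)c2Cl)[nH]c1=O` and compound 3 `C=CCn1c(=O)/c(=C\c2cccc(Br)c2)[nH]c(=O)/c1=C\c1cccc(Br)c1` share their core with compound 2 `C=CCn1c(=O)/c(=C\c2cc(Br)ccc2F)[nH]c(=O)/c1=C\c1ccccc1OC`, and in a functional assay on HeLa cells (Homo sapiens) for cytotoxicity, read by CCK-8 assay, with a stated time of 72 h (on this read-out lower numbers stand for stronger inhibition and higher numbers for weaker inhibition), compound 1 gives "not active" (no number reported) while compound 3 gives "not active" (no number reported), neither result being a number. In this assay compound 2 gives 34600 nM, which is the only figure reported among the three; the other two entries carry no single number, so compound 2 stands alone as the one quantified case. Compound 4 `C=CCn1c(=O)/c(=C\c2cc(F)ccc2C)[nH]c(=O)/c1=C\c1ccccc1OC` has not yet been tested, and it differs from compound 2 by 5-fluoro-2-methylphenyl in place of 5-bromo-2-fluorophenyl on a double-bonded chain carbon bound to an aromatic carbon. For the measured compounds named here, with no step between measured compounds to guide this change, only a small shift is expected, a 1.2-fold higher number from compound 2 to compound 4 (0.06 log units; within the scatter), staying within the usual scatter in either direction. Compound 4 is therefore estimated at 40000 nM, with a range from 15000 nM to 120000 nM.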

Compound 4, half-maximal inhibitory concentration: 2900 nM
For compound 4 the middle estimate is 14-fold (1.14 log units) above the measured one, and the stated range ends above it.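

In this assay, 5-fluoro-2-methylphenyl in place of 5-bromo-2-fluorophenyl gives a 12-fold lower number from compound 2 to compound 4 (1.08 log units; beyond the scatter), so the aryl group on this double-bonded chain carbon can move the number well beyond the scatter. For the compounds shown here, the earlier compounds offered no measured step at this place, so this is the first sign that it responds to a change. No measurement available here explains the drop. As far as these compounds go, it remains open which part of the exchange carries the step, the methyl group or the loss of bromine. From the compounds shown here alone, it also remains open whether an amine or a carboxylic acid in place of that methyl would keep the gain.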